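A few compounds are considered here, and "the series" means these few. Any claim that something is new, unique, unknown or untested is made for them only; others in the source may bear on it.

Working notes on the series. Among the measured compounds shown here, in an assay on FRT-Jurkat cells for inhibition of nuclear factor NF-kappa-B complex (Homo sapiens), read by flow cytometry, with a stated time of 24 h, tested at 10 uM (on this read-out lower numbers stand for less inhibition and higher numbers for more inhibition at the one concentration tested (going by the name of the read-out)), compound 1 `COc1ccc(Nc2cccc3c2C(=O)N(C2CCC(=O)NC2=O)C3=O)cc1` gives 13%, the highest of the three numbers in hand, though compound 3 `CCc1ccc(Nc2ccc3c(c2)C(=O)N(C2CCC(=O)NC2=O)C3=O)cc1`, with 5%, lies within the scatter of it; compound 2 `CN(c1ccccc1)c1ccc2c(c1)C(=O)N(C1CCC(=O)NC1=O)C2=O` gives -2%, the one value beyond the scatter from compound 1. For the measured compounds named here, the single measured step, a number 7 percentage points higher from compound 2 to compound 3 (within the scatter), is itself within the scatter. Compound 4 `CCCc1ccc(Nc2cccc3c2C(=O)N(C2CCC(=O)NC2=O)C3=O)cc1` differs from compound 1 by propyl in place of methoxy on an aromatic carbon. Going by the values given here, no measured step exchanges methoxy for propyl, so nothing in hand bears directly on this change, and the one step that was measured was small. The expectation is therefore no step beyond the scatter in this assay, a number 1 percentage points lower from compound 1 to compound 4 (within the scatter). Compound 4 is estimated at 12%, range -2% to 25%.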

Compound 4, a percentage reported as inhibition, at one concentration (the size of the read-out at that concentration, not a potency): 23%
The estimate for compound 4 lay 11 percentage points below the measured number; the range from low to high includes it.
By their numbers in this assay, from the lowest: compounds 2, 3, 1 and 4 (each within the scatter of the next, the first and the last beyond it).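

At this place, para to a large group, going from 4-methoxyphenyl to 4-propylphenyl gives in this assay a number 10 percentage points higher from compound 1 to compound 4 (within the scatter), so the two groups are not told apart in this read-out. The oxygen of methoxy is thus not required for a reading in this range, at least with propyl as the replacement. Nothing measured bears on the reason for this result.

Going by these compounds, whether an amine, a carboxylic acid or a longer chain such as hexyl at the same place would give a step beyond the scatter stays open.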